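Dimethylpiperidine to methylpiperazine: a step toward weaker growth inhibition

The compounds below may be only part of what the source reports. "The series", "measured", "known", "first", "only" and "open" are said of these compounds alone.

Compound 1 `N#Cc1ccc(Nc2nc(Oc3ccnc4ccccc34)nc(N3CCN(c4ccccc4Cl)CC3)n2)cc1C(F)(F)F` gives > 100000 nM in a functional assay on DU-145 cells (Homo sapiens) for cytotoxicity, read by sulforhodamine B assay, with a stated time of 48 h (a lower number here means a stronger inhibitor of growth, a higher number a weaker inhibitor of growth), which is a limit of the assay.
Compound 2 `CC(=O)N1CCN(c2nc(Nc3ccc(C#N)c(C(F)(F)F)c3)nc(Oc3ccnc4ccccc34)n2)CC1` gives > 100000 nM in this assay, again a limit.
Compound 3 `CC1CC(C)CN(c2nc(Nc3ccc(C#N)c(C(F)(F)F)c3)nc(Oc3ccnc4ccccc34)n2)C1` gives 68000 nM in this assay.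

For the measured compounds named here, compound 3 therefore holds the only actual number among the three compounds; the other two results sit at the limit of > 100000 nM in this assay, at which 2 of the 3 values shown sit. The step that the two limits leave unreadable from compound 1 to compound 2 cannot be read, as both ends are limits. The step of an at least 1.4-fold lower number from compound 2 to compound 3 (0.16 log units; that floor lies within the scatter) is the only readable one, and its floor lies within the scatter, so compound 3 is at best slightly stronger than compound 2.

Compound 4 `CN1CCN(c2nc(Nc3ccc(C#N)c(C(F)(F)F)c3)nc(Oc3ccnc4ccccc34)n2)CC1` carries the change (4-methylpiperazin-1-yl in place of 3,5-dimethylpiperidin-1-yl on an aromatic carbon). Going by the values given here, the step that bears on it is the one from compound 2 to compound 3, which runs in the opposite direction: replacing the acetylpiperazine with the dimethylpiperidine gave a number where the acetyl analogue gave only a limit. Compound 4 returns to a piperazine, now methylated, so the expectation is a move back toward the limit, a step of a 1.5-fold higher number from compound 3 to compound 4 (0.17 log units; within the scatter) that may or may not exceed the scatter. Compound 4 is thus expected to give about 100000 nM, with a range from 40000 nM to 250000 nM, and a fair chance that only a limit is reported.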

Compound 4, concentration for total growth inhibition: > 100000 nM
Compound 4: no number, only a limit; the forecaster's own chance of this, stated with the estimate: 50%; the middle value lies on the limit itself.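

At this place on the shared core, opposite the ring nitrogen, the second ring nitrogen and the loss of the two ring methyl groups leave this assay with only a limit for compound 4, where the 3,5-dimethylpiperidin-1-yl group had given a number. All that can be read of this change is an at least 1.4-fold higher number from compound 3 to compound 4 (0.16 log units; that floor lies within the scatter), so the result does not establish that 4-methylpiperazin-1-yl truly weakens growth inhibition relative to 3,5-dimethylpiperidin-1-yl. The steps among compounds 1, 2 and 4 cannot be read, as both ends of each are limits, and the new result extends the picture to a third piperazine, with a methyl, an acetyl or a 2-chlorophenyl group on the ring nitrogen, leaving the piperidine compound 3 as the one exception: the limit of > 100000 nM in this assay, at which 3 of the 4 values shown sit.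

As far as these compounds go, what stays open is whether the number of compound 3 rests on its two methyl groups or on the absence of the second ring nitrogen, a question that a plain piperidin-1-yl or a morpholin-4-yl group at this place could help to separate. From the compounds shown here alone, how far compounds 1, 2 and 4 lie from one another also stays unknown.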